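Compound 2 to compound 3: trifluoromethoxy leaves

The source may report more compounds than this note shows. Statements on the series, on what has been measured and on what is new or still open speak of the compounds shown alone.

In an ADME assay on LLC-PK1 cells (Sus scrofa) for permeability, with a stated time of 3 h, tested at 1 uM (a lower number here means that the compound crosses the layer more slowly, a higher number that the compound crosses the layer faster), compound 2 (`O=C(O)CNC(=O)c1c(O)c2c(n(Cc3ccc(OC(F)(F)F)cc3)c1=O)COC2`) gives 5.2 10^-6 cm/s and compound 1 (`O=C(O)CNC(=O)c1c(O)c2c(n(Cc3ccc(C(F)(F)F)cc3)c1=O)COC2`) gives 4.2 10^-6 cm/s. Among the compounds with values here, these two values lie within the scatter of each other, so compound 2 stands level with its only measured neighbour.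

Compound 3 (`CC(C)(O)c1ccc(Cn2c3c(c(O)c(C(=O)NCC(=O)O)c2=O)COC3)cc1`) keeps the shared core and the glycine-derived side chain of compound 2, but has 1-hydroxy-1-methylethyl in place of trifluoromethoxy on an aromatic carbon. Within the data shown here, only one measured step bears on this change, and it is a weak guide. The step of a 1.2-fold higher number from compound 1 to compound 2 (0.09 log units; within the scatter) replaces trifluoromethyl with trifluoromethoxy and stays within the scatter. It exchanges one fluorine-bearing group for another, whereas the new change removes all fluorine and brings in a hydroxyl hydrogen-bond donor. Among the measured compounds shown here, the series holds no measured step of that kind, so the direction rests on judgement and remains uncertain. A lower number is expected in this assay, and the estimated step is a 2.4-fold lower number from compound 2 to compound 3 (0.37 log units; beyond the scatter). For compound 3 the estimated value is 2.2 10^-6 cm/s, with an expected range of 0.8 10^-6 cm/s to 5 10^-6 cm/s.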

Compound 3, apparent permeability: < 1.5 10^-6 cm/s
Compound 3: a limit, no number; the forecaster's own chance of this, stated with the estimate: 10%; at least 1.4-fold (0.16 log units) between middle value and limit.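

In this assay compound 3 gives < 1.5 10^-6 cm/s, which is a limit of the assay and not a number. Within the data shown here, on an aromatic carbon para to a large group, the two fluorine-bearing groups stood within the scatter of each other, whereas 1-hydroxy-1-methylethyl brings the first changes at this place that lie beyond it: an at least 3.4-fold lower number from compound 2 to compound 3 (0.53 log units; beyond the scatter) and an at least 2.8-fold lower number from compound 1 to compound 3 (0.44 log units; beyond the scatter). This change, which removes all fluorine and brings in a hydrogen-bond donor, therefore shows that the read-out does respond to the group at this place, though only a minimum size can be read for either step, and the series holds one such reading: the limit of < 1.5 10^-6 cm/s in this assay, at which 1 of the 3 values shown sits.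

The compounds shown do not separate the part played by the hydroxyl from that played by the loss of fluorine, and a tert-butyl group at the same place would set the two apart. As far as these compounds go, how an amine or a carboxylic acid there would read in this assay also remains open, as does the true value of compound 3.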